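Amide Substituent Swap and Tolerated Concentration in Liver Cells

The source may hold more compounds than are shown below. What is called first, only, known or untested is meant among the compounds shown, and "the series" means these compounds.

Compound 1 `O=C(/C=C/c1coc2cc(O)ccc2c1=O)NCc1ccccc1`: 436000 nM
Compound 2 `COc1ccc2c(=O)c(/C=C/C(=O)NCc3cccc(F)c3)coc2c1`: 475000 nM

Both numbers come from an ADME assay on HepG2 2.2.15 cells (Homo sapiens) for cytotoxicity, read by MTT assay, with stated times of 48 h and 9 days; a lower number here means that less compound is tolerated, a higher number that more compound is tolerated. Compound 2 gives 475000 nM, the higher of the two, but compound 1 sits within the scatter of it, so the two cannot be told apart. Compound 3 `CCOc1ccc(NC(=O)/C=C/c2coc3cc(OC)ccc3c2=O)cc1` is not yet measured. It differs from compound 2 in one place: 4-ethoxyphenyl in place of 3-fluorobenzyl on an amide-type nitrogen. Within the data shown here, no measured pair shows what such a change does, so no movement beyond the scatter is expected; the step of a 1.2-fold lower number from compound 2 to compound 3 (0.07 log units; within the scatter) is expected to be small. Compound 3 is estimated at 400000 nM, likely between 200000 nM and 800000 nM.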

Compound 3, half-maximal cytotoxic concentration: 460000 nM
Beside the measured number, compound 3's estimate is 1.2-fold (0.06 log units) below it; measured number inside the range.
By their numbers in this assay, from the lowest: compounds 1, 3 and 2 (each within the scatter of the next).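

In this assay, putting 4-ethoxyphenyl in place of 3-fluorobenzyl on the amide-type nitrogen gives a 1.0-fold lower number from compound 2 to compound 3 (0.01 log units; within the scatter) and leaves the two compounds indistinguishable. This first one-place comparison shows that, at this position, these two different aromatic groups are not separated by this read-out. Nothing measured here offers a reason for that result. Still open, from the compounds shown here alone, is whether a group of another kind on this nitrogen, such as a carboxylic acid or an amine on a longer chain, would move the tolerated concentration beyond the usual scatter.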